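A few compounds are considered here, and "the series" means these few. Any claim that something is new, unique, unknown or untested is made for them only; others in the source may bear on it.

Compound 1, `CCC(COC)N(C)c1nc(C)nc2c1nnn2-c1ccc(C(C)C)cc1Br`, in an in vitro assay on 293-EBNA cells for binding affinity to corticotropin-releasing factor receptor 1 (Homo sapiens) (on this read-out higher numbers stand for weaker inhibition and lower numbers for stronger inhibition), compound 1 gives 11.2 nM.
Compound 2, `CCCCN(CC)c1nc(C)nc2c1nnn2-c1ccc(C(C)C)cc1Br`, in this assay compound 2 gives 7.5 nM.
Compound 3, `CCN(c1nc(C)nc2c1nnn2-c1ccc(C(C)C)cc1Br)C(COC)COC`, in this assay compound 3 gives 123 nM.

Among these three, compound 3 stands highest, that is weakest: its number lies an 11-fold higher number from compound 1 to compound 3 (1.04 log units; beyond the scatter) and a 16-fold higher number from compound 2 to compound 3 (1.21 log units; beyond the scatter), both steps well beyond the scatter. The three compounds share one core and differ only in the amino group on an aromatic carbon of that core. Compound 4, `COCC(C)(C)Nc1nc(C)nc2c1nnn2-c1ccc(C(C)C)cc1Br`, carries the change (a group of 7 heavy atoms (5 carbon, 1 nitrogen, 1 oxygen; no ring) in place of a group of 10 heavy atoms (7 carbon, 1 nitrogen, 2 oxygen; no ring), on an aromatic carbon).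

Among the measured compounds shown here, two measured steps bear on this. Building up the amino group from compound 1 or compound 2 to the two-methoxymethyl branch of compound 3 cost a great deal: an 11-fold higher number from compound 1 to compound 3 (1.04 log units; beyond the scatter) and a 16-fold higher number from compound 2 to compound 3 (1.21 log units; beyond the scatter). Compound 4 undoes that bulk, returning to a smaller group, so a sizeable fall in this assay is expected, though compound 4 is the only one with a hydrogen-bond donor on that nitrogen, and nothing measured shows how that counts. The expected step is a 4.1-fold lower number from compound 3 to compound 4 (0.61 log units; beyond the scatter). Compound 4 is therefore estimated at 30 nM, within a range from 8 nM to 120 nM.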

Compound 4, inhibition constant: 195 nM
Compound 4: middle estimate off by 6.5-fold (0.81 log units), on the low side, outside the stated range (above it).
By their numbers in this assay, from the lowest: compounds 2 and 1 (each within the scatter of the next); then compounds 3 and 4 (each within the scatter of the next).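

Replacing the larger group with (1-(methoxymethyl)-1-methylethyl)amino on this aromatic carbon gives no measurable gain in this assay (a 1.6-fold higher number from compound 3 to compound 4 (0.20 log units; within the scatter)), so a smaller group is not enough to reach the numbers of the first two compounds. Heavy-atom count does not settle it either: butyl(ethyl)amino has as many heavy atoms as the entering group, yet the step to it is large (a 26-fold higher number from compound 2 to compound 4 (1.41 log units; beyond the scatter)), and the step from the group of compound 1 is large too (a 17-fold higher number from compound 1 to compound 4 (1.24 log units; beyond the scatter)). Nothing available explains these results.

Compound 4 differs from compound 1 and compound 2 both in its hydrogen-bond donor and in the shape of its chain, and the compounds shown cannot separate the two. A plain butylamino group, or a methyl added to the nitrogen of compound 4, would help to tell them apart.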